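From propyl to sec-butyl: expected clearance of compound 3

The compounds below may be only part of what the source reports. "The series", "measured", "known", "first", "only" and "open" are said of these compounds alone.

Compound 1 `CCC[C@@H]1NC[C@@H](C)Oc2ccccc2CCCNC(=O)[C@@H](Cc2ccc(F)cc2)NC(=O)[C@@H](C)N(C)C1=O`: 41 mL/min/kg
Compound 2 `C[C@@H]1C(=O)N[C@H](Cc2ccc(F)cc2)C(=O)NCCCc2ccccc2OCCN[C@@H](C2CC2)C(=O)N1C`: 72 mL/min/kg

In an in vivo ADME assay on the whole organism (strain Sprague-Dawley) for pharmacokinetics, with Rattus norvegicus as the target (on this read-out lower numbers stand for slow clearance and higher numbers for fast clearance), compound 1 gives 41 mL/min/kg and compound 2 gives 72 mL/min/kg. These two values lie within the usual scatter of each other, so compound 1 cannot be told apart from compound 2 on this read-out.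

Compound 3 `CC[C@H](C)[C@@H]1NC[C@@H](C)Oc2ccccc2CCCNC(=O)[C@@H](Cc2ccc(F)cc2)NC(=O)[C@@H](C)N(C)C1=O` keeps the core of compound 1 and differs in one place: methyl in place of hydrogen on a saturated chain carbon bound to a saturated chain carbon and a saturated ring carbon. This is methyl in place of hydrogen on a saturated chain carbon bound to a saturated chain carbon and a saturated ring carbon, which turns propyl into sec-butyl. Within the data shown here, compounds 1 and 2 differ in more than one place, and no measured pair isolates this change, so the data offer no direct guide to its size. With that gap, no shift beyond the scatter is expected in this assay, and the expectation starts from compound 1 at 41 mL/min/kg. The expected change is a 1.1-fold higher number from compound 1 to compound 3 (0.04 log units; within the scatter). For compound 3 the estimated value is 45 mL/min/kg, with an expected range of 22 mL/min/kg to 85 mL/min/kg.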

Compound 3, clearance: 40 mL/min/kg
Compound 3: the middle estimate sits 1.1-fold (0.05 log units) above what was measured; measured number inside the range.
By their numbers in this assay, from the lowest: compounds 3, 1 and 2 (each within the scatter of the next).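

In this assay, among these compounds, compounds 1 and 3 form the only pair here that differs in one place, so the effect of a single change can be read for the first time. Methyl in place of hydrogen on a saturated chain carbon bound to a saturated chain carbon and a saturated ring carbon, which turns propyl into sec-butyl, gives a 1.0-fold lower number from compound 1 to compound 3 (0.01 log units; within the scatter). This read-out therefore cannot tell the two compounds apart, so at this position the extra methyl leaves no measurable mark on clearance in the rat, and no supporting measurement is available to explain that result.

Among the compounds shown here, this single step covers only one small change to a saturated chain, so it remains open whether a longer chain such as hexyl, or a chain ending in an amine or a carboxylic acid, would stay within the scatter of compound 1 or move beyond it. Going by these compounds, it is also open whether the same methyl would give a similar result on a different core.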